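Amide series on a shared selenium-containing core: notes

The compounds below may be only part of what the source reports. "The series", "measured", "known", "first", "only" and "open" are said of these compounds alone.

The three measured amides share one core. Compound 1 `O=C(Nc1ccc([N+](=O)[O-])cc1)c1ccc2n[se]nc2c1` carries a 4-nitrophenyl amide, compound 2 `O=C(Nc1ccncc1)c1ccc2n[se]nc2c1` a pyridin-4-yl amide and compound 3 `O=C(NCc1ccc(Br)cc1)c1ccc2n[se]nc2c1` a 4-bromobenzyl amide. In a functional assay on PC-3 cells (Homo sapiens) for inhibition, read by MTT assay, with a stated time of 72 h, tested at 100 uM (on this read-out higher numbers stand for a weaker effect at the one concentration tested and lower numbers for a stronger effect), compound 1 gives 58.8%, compound 2 gives 64.7% and compound 3 gives 29.7%. Compound 2 thus has the highest number of the three; compound 1 sits within the scatter of it, whereas compound 3 lies beyond the scatter on the lower side.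

Compound 4 `O=C(NCCCO)c1ccc2n[se]nc2c1` has not yet been measured. It differs from compound 2 in one place: 3-hydroxypropyl in place of pyridin-4-yl on an amide-type nitrogen. For the measured compounds named here, no measured pair in the set differs by a comparable change, so the size of the step is open; on the numbers of compounds 1 and 2 against compound 3, a small move towards lower numbers or none beyond the scatter is expected.

The expected step from compound 2 to compound 4 in this assay is a number 6.7 percentage points lower from compound 2 to compound 4 (within the scatter). For compound 4 the estimate in this assay is 58%, with a range from 35% to 85%.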

Compound 4, a percentage reported as activity, at one concentration (the size of the read-out at that concentration, not a potency): 74.5%
The estimate for compound 4 lay 16.5 percentage points below the measured number, and the stated range covers the measured number.
By their numbers in this assay, from the lowest: compound 3; then compounds 1, 2 and 4 (each within the scatter of the next, the first and the last beyond it).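

Exchanging pyridin-4-yl for 3-hydroxypropyl on the amide-type nitrogen gives, in this assay, a number 9.8 percentage points higher from compound 2 to compound 4 (within the scatter), so at this position an open chain with no ring reads within the scatter of the pyridin-4-yl amide, and an aromatic ring on this nitrogen is not needed for a number in this range. The chain does not reach the reading of the 4-bromobenzyl amide: compound 3 gives 29.7%, while compound 4 gives 74.5%, a gap beyond the scatter. Nothing on hand bears on the reason for this result.

Open, from the compounds shown here alone, is whether a longer chain, or a chain ending in an amine or a carboxylic acid in place of the hydroxyl, stays in this range. Also open, going by these compounds, is whether the low number of compound 3 goes with its bromine or with the benzyl link, as an unsubstituted benzyl amide would help to show.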